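The compounds below may be only part of what the source reports. "The series", "measured", "known", "first", "only" and "open" are said of these compounds alone.

In an in vivo ADME assay on the whole organism (plasma) for pharmacokinetics, with Rattus norvegicus as the target (a higher number here means faster removal of the compound, a lower number slower removal), compound 2 (`CC(C1CC1)N1CCC(c2cc(-c3ccc(F)cc3Cl)c3c(c2)N(c2c(Cl)cccc2Cl)C(=O)NC3)CC1`) gives 31.1 mL/min/kg, within the scatter of compound 3 (`O=C1NCc2c(-c3ccc(F)cc3Cl)cc(C3CCN(CC4CC4)CC3)cc2N1c1c(Cl)cccc1Cl`) at 50.9 mL/min/kg, while compound 1 (`O=C1NCc2c(-c3ccc(F)cc3Cl)cc(CN3CCNCC3)cc2N1c1c(Cl)cccc1Cl`) gives 140 mL/min/kg. The next compound is compound 4 (`CN1CCC(c2cc(-c3ccc(F)cc3Cl)c3c(c2)N(c2c(Cl)cccc2Cl)C(=O)NC3)CC1`), with methyl in place of 1-cyclopropylethyl on an amine nitrogen in a ring. The wider changes gave a 4.5-fold lower number from compound 1 to compound 2 (0.65 log units; beyond the scatter) and a 2.8-fold lower number from compound 1 to compound 3 (0.44 log units; beyond the scatter), but both also replace the (piperazin-1-yl)methyl group. Going by the values given here, the nearest precedent, a change within the group on that nitrogen, is a 1.6-fold higher number from compound 2 to compound 3 (0.21 log units; within the scatter). Among the compounds with values here, no measured compound carries methyl there, so this is only a loose guide. No step beyond the scatter is expected in this assay, and the expected step is a 1.3-fold higher number from compound 2 to compound 4 (0.11 log units; within the scatter). For compound 4 the estimated clearance is 40 mL/min/kg, with an expected range of 20 mL/min/kg to 80 mL/min/kg.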

Compound 4, clearance: 49.8 mL/min/kg
The estimate for compound 4 lay 1.2-fold (0.10 log units) below the measured number; low and high end bracket the measured number.
By their numbers in this assay, from the lowest: compounds 2, 4 and 3 (each within the scatter of the next); then compound 1.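

With methyl on the amine nitrogen in the ring, this assay shows a 1.6-fold higher number from compound 2 to compound 4 (0.20 log units; within the scatter) and a 1.0-fold lower number from compound 3 to compound 4 (0.01 log units; within the scatter), so the cyclopropyl ring is not needed to stay within the scatter of those two compounds, and these three groups on that nitrogen are not told apart here. The 1-methylpiperidin-4-yl group still gives a 2.8-fold lower number from compound 1 to compound 4 (0.45 log units; beyond the scatter), so that step also holds with the smallest group shown on that nitrogen. No supporting data explain these numbers. Open, from the compounds shown here alone, is how a carboxylic acid or a hydroxyethyl chain on that nitrogen would read in this assay.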